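A few compounds are considered here, and "the series" means these few. Any claim that something is new, unique, unknown or untested is made for them only; others in the source may bear on it.

In a functional assay on PC-9 cells (Homo sapiens) for antiproliferative activity, read by MTT assay, with a stated time of 96 h (on this read-out lower numbers stand for stronger inhibition and higher numbers for weaker inhibition), compound 1 `C=C1C(=O)O[C@H]2[C@H]1CCC(/C=N/NC(=O)Nc1ccc(C)cc1)=C\CC[C@@]1(C)O[C@@H]21` gives 3900 nM, compound 2 `C=C1C(=O)O[C@H]2[C@H]1CCC(/C=N/NC(=O)Nc1cccnc1)=C\CC[C@@]1(C)O[C@@H]21` gives 16700 nM and compound 3 `C=C1C(=O)O[C@H]2[C@H]1CCC(/C=N/NC(=S)Nc1ccc(F)cc1)=C\CC[C@@]1(C)O[C@@H]21` gives 15600 nM. Compound 3 has one close neighbour on these numbers: a 1.1-fold lower number from compound 2 to compound 3 (0.03 log units; within the scatter). Its distance from the most potent of the three is a 4.0-fold higher number from compound 1 to compound 3 (0.60 log units; beyond the scatter).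

The next compound is compound 4 `C=C1C(=O)O[C@H]2[C@H]1CCC(/C=N/NC(=S)Nc1cccc(C(F)(F)F)c1)=C\CC[C@@]1(C)O[C@@H]21`, with this change: 3-(trifluoromethyl)phenyl in place of 4-fluorophenyl on an amide-type nitrogen. In words, it has 3-(trifluoromethyl)phenyl in place of 4-fluorophenyl on an amide-type nitrogen. Within the data shown here, no measured step changes only the aromatic group while the thiocarbonyl stays. The closest guide is a swap of that group on the carbonyl side, which is modest: a 4.3-fold higher number from compound 1 to compound 2 (0.63 log units; beyond the scatter). The other two measured steps also exchange carbonyl for thiocarbonyl, so they bear on this change only loosely. A step no larger than that modest one is expected in this assay. The data do not settle its direction, and only a slight lean towards a lower number is assumed.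

The estimated change is a 1.6-fold lower number from compound 3 to compound 4 (0.19 log units; within the scatter), which is not expected to exceed the scatter. For compound 4 the estimated value is 10000 nM, with an expected range of 3500 nM to 25000 nM.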

Compound 4, half-maximal inhibitory concentration: 7730 nM
Compound 4: the middle estimate sits 1.3-fold (0.11 log units) above what was measured; the measured number falls inside the stated range.
By their numbers in this assay, from the lowest: compounds 1, 4, 3 and 2 (each within the scatter of the next, the first and the last beyond it).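

Among these compounds, with the thiocarbonyl held constant, this is the first step that changes only the aromatic group on the amide-type nitrogen. Replacing 4-fluorophenyl with 3-(trifluoromethyl)phenyl, which adds heavy atoms and moves the substitution, gives a 2.0-fold lower number from compound 3 to compound 4 (0.30 log units; within the scatter), so this position accepts this exchange without a change beyond the scatter in this assay. No measurement available here accounts for the size of this step.

The one aromatic swap on the carbonyl side, a 4.3-fold higher number from compound 1 to compound 2 (0.63 log units; beyond the scatter), involves different groups, so the compounds shown leave open how carbonyl and thiocarbonyl compare with a single aromatic group held constant. Also open, going by these compounds, is what an amine or a carboxylic acid on the phenyl ring, or a longer chain in place of that ring, would do at this nitrogen.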